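A Phenyl Group Enters the Core of Compound 1

The source may report more compounds than this note shows. Statements on the series, on what has been measured and on what is new or still open speak of the compounds shown alone.

Within the data shown here, compound 1 `NC(=S)N/N=C(\COc1ccccc1)c1ccc(Br)cc1` gives 54900 nM in an ADME assay on L929 cells (Mus musculus) for cytotoxicity, read by resazurin assay, with a stated time of 96 h (on this read-out higher numbers stand for lower toxicity in this test and lower numbers for higher toxicity in this test), the highest of the two numbers measured so far; its nearest neighbour is compound 2 `NC(=S)N/N=C(\COc1ccccc1Cl)c1ccc(Br)cc1`, which gives 25100 nM in this assay. Among the measured compounds shown here, the single measured step, a 2.2-fold lower number from compound 1 to compound 2 (0.34 log units; beyond the scatter), is a modest drop. Compound 3 `NC(=S)N/N=C(\COc1ccc(-c2ccccc2)cc1)c1ccc(Br)cc1` differs from compound 1 by phenyl in place of hydrogen on an aromatic carbon. For the measured compounds named here, no measured pair bears directly on this change; the chloro step is the only guide, and it points toward a lower number. A step of roughly that size is therefore expected, a 2.2-fold lower number from compound 1 to compound 3 (0.34 log units; beyond the scatter). Compound 3 is estimated at 25000 nM, within a likely range from 8000 nM to 60000 nM.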

Compound 3, half-maximal cytotoxic concentration: 90800 nM
Compound 3: middle estimate off by 3.6-fold (0.56 log units), on the low side, outside the stated range (above it).
By their numbers in this assay, from the lowest: compound 2; then compounds 1 and 3 (each within the scatter of the next).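

In this assay the added ring leaves the number within the scatter (a 1.7-fold higher number from compound 1 to compound 3 (0.22 log units; within the scatter)), so phenyl in place of hydrogen, with its 6 carbon atoms, para to a large group, does not shift the reading measurably. The chloro step (a 2.2-fold lower number from compound 1 to compound 2 (0.34 log units; beyond the scatter)) lay beyond the scatter, and this one does not. No evidence on the cause of this result is available. Still open, as far as these compounds go, is whether an amine or a carboxylic acid on this same aromatic carbon would also leave the number within the scatter.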